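A few compounds are considered here, and "the series" means these few. Any claim that something is new, unique, unknown or untested is made for them only; others in the source may bear on it.

Measured so far:
- compound 1 `C=CS(=O)(=O)N1CCN(c2nc(OC[C@H]3CCCN3C)nc3sc(-c4ccc(N5CCN(C)CC5)cc4)cc23)CC1` — 760 nM
- compound 2 `CN1CCN(c2ccc(-c3cc4c(N5CCN(S(=O)(=O)N6CCCCC6)CC5)ncnc4s3)cc2)CC1` — 8130 nM

Both compounds were tested in a functional assay on MDA-MB-231 cells (Homo sapiens) for antiproliferative activity, read by MTT assay, with a stated time of 48 h; on this read-out lower numbers stand for stronger inhibition and higher numbers for weaker inhibition. Of the two numbers, compound 2 has the higher one, and the gap to compound 1 is beyond the usual scatter, so compound 2 is the weaker of the pair on this read-out. Going by the values given here, the two structures differ in more than one place, so no single step between them can be drawn.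

Compound 3 `COc1ccccc1NC(=O)N1CCN(c2ncnc3sc(-c4ccc(N5CCN(C)CC5)cc4)cc23)CC1` has not yet been measured. It keeps the shared core and differs from compound 2 in one place: (2-methoxyphenyl)carbamoyl in place of (piperidin-1-yl)sulfonyl on an amine nitrogen in a ring. Among the compounds with values here, there is no measured pair that isolates this change, so any expectation rests on compound 2 alone as a starting point.

The step from compound 2 to compound 3 is expected to be a 2.7-fold lower number from compound 2 to compound 3 (0.43 log units; beyond the scatter), a moderate move toward stronger inhibition, though a result within the scatter would not be surprising. Compound 3 is estimated at 3000 nM, with a plausible range from 800 nM to 12000 nM.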

Compound 3, half-maximal inhibitory concentration: 23200 nM
Beside the measured number, compound 3's estimate is 7.7-fold (0.89 log units) below it; the measured number lies above the stated range.
By their numbers in this assay, from the lowest: compound 1; then compound 2; then compound 3.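

Going by these compounds alone, on the amine nitrogen in the ring, (2-methoxyphenyl)carbamoyl in place of (piperidin-1-yl)sulfonyl gives a 2.9-fold higher number from compound 2 to compound 3 (0.46 log units; beyond the scatter) in this assay as the first change at this position that can be read on its own. The direction is toward weaker inhibition, so the group on this nitrogen affects the read-out, and this replacement, which adds an aromatic ring and a hydrogen-bond donor, does not improve on the group it replaces. No measurement here accounts for the shift, and this single step cannot show which part of the entering group matters.

The compounds shown leave open how a smaller group on this nitrogen, such as acetyl or methanesulfonyl, would read. They also leave open whether a plain phenylcarbamoyl group, without the methoxy, would read differently from (2-methoxyphenyl)carbamoyl.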